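Cyclohexylamino in place of pyrrolidin-1-yl on a carbonyl carbon

The compounds below may be only part of what the source reports. "The series", "measured", "known", "first", "only" and "open" are said of these compounds alone.

Three related compounds have so far been measured in a functional assay on BXPC-3 cells (Homo sapiens) for cytotoxicity, read by fluorescence, with a stated time of 48 h (on this read-out higher numbers stand for an effect only at larger amounts of compound and lower numbers for an effect already at smaller amounts), and form the basis for this estimate. Compound 2 (`CC(C)=CCC/C(C)=C/CC/C(C)=C/CSC[C@H](NC(=O)CCCCCN1CCN(C)CC1)C(=O)N1CCCC1`) gives 3200 nM as the lowest of the three numbers. Compound 3 (`CC(C)=CCC/C(C)=C/CC/C(C)=C/CSC[C@H](NC(=O)CCCCCN1CCCC1)C(=O)N1CCCC1`) stands at 6500 nM and compound 1 (`CC(C)=CCC/C(C)=C/CC/C(C)=C/CSC[C@H](NC(=O)CCCCCN1CCCC1)C(=O)NC1CCCCC1`) at 12700 nM on the same scale.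

The step from compound 2 leads to the unmeasured compound 4 (`CC(C)=CCC/C(C)=C/CC/C(C)=C/CSC[C@H](NC(=O)CCCCCN1CCN(C)CC1)C(=O)NC1CCCCC1`), which carries cyclohexylamino in place of pyrrolidin-1-yl on a carbonyl carbon. One measured step makes the same exchange in the opposite direction, with a 2.0-fold lower number from compound 1 to compound 3 (0.29 log units; within the scatter) on going from cyclohexylamino to pyrrolidin-1-yl. The other measured step, with a 2.0-fold higher number from compound 2 to compound 3 (0.31 log units; beyond the scatter) as its size, concerns a different part of the molecule, one that compound 2 and compound 4 share. For the measured compounds named here, no measured pair tests the exchange with that shared group in place, so the first step is simply carried over in reverse.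

In this assay a modest rise is therefore expected, at about the edge of the scatter, and a 2.0-fold higher number from compound 2 to compound 4 (0.29 log units; within the scatter) is the estimated step. For compound 4 the expected value is 6300 nM and the estimated range runs from 3300 nM to 12000 nM at this stage.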

Compound 4, half-maximal effective concentration: 12000 nM
Beside the measured number, compound 4's estimate is 1.9-fold (0.28 log units) below it; measured number inside the range.
By their numbers in this assay, from the lowest: compound 2; then compounds 3, 4 and 1 (each within the scatter of the next).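

In this assay, cyclohexylamino in place of pyrrolidin-1-yl on a carbonyl carbon can now be read on a second core, where it gives a 3.8-fold higher number from compound 2 to compound 4 (0.57 log units; beyond the scatter), whereas the earlier reading of this exchange stayed within the scatter. The direction is the same on both cores, and the two sizes agree as far as two such steps can show: the same change on two cores in this assay, a 2.0-fold lower number (0.29 log units; within the scatter) from compound 1 to compound 3 and a 3.8-fold lower number (0.57 log units; beyond the scatter) from compound 4 to compound 2, 1.9-fold (0.28 log units) apart, within the scatter of two such steps. The chain position also gains a second reading, as 4-methylpiperazin-1-yl in place of pyrrolidin-1-yl with cyclohexylamino on the carbonyl carbon gives a 1.1-fold lower number from compound 1 to compound 4 (0.02 log units; within the scatter), and this reading too is compatible with the earlier one on the other core: the same change on two cores in this assay, a 2.0-fold higher number (0.31 log units; beyond the scatter) from compound 2 to compound 3 and a 1.1-fold higher number (0.02 log units; within the scatter) from compound 4 to compound 1, 1.9-fold (0.28 log units) apart, within the scatter of two such steps.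

The compounds shown hold only two groups at each of the two positions, and the exchange on the carbonyl carbon alters ring size and the hydrogen-bond donor count together, so methyl(cyclohexyl)amino or piperidin-1-yl there would be needed to separate the two. From the compounds shown here alone, how morpholin-4-yl at the end of the chain, or a shorter or longer chain, would read in this assay also stays open.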